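The source may hold more compounds than are shown below. What is called first, only, known or untested is meant among the compounds shown, and "the series" means these compounds.

Among the measured compounds shown here, compound 2 `CN1[C@@H]2c3[nH]c4ccccc4c3C[C@H]1[C@H](C#N)N1[C@@H](CNC(=O)c3cc4ccccc4o3)c3[nH]c4ccccc4c3C[C@@H]21` gives the lowest of the two numbers measured so far in a functional assay on A2780 cells (Homo sapiens) for cytotoxicity, read by MTT assay, with a stated time of 72 h (on this read-out lower numbers stand for stronger inhibition and higher numbers for weaker inhibition), at 230 nM. For the measured compounds named here, its nearest neighbour, compound 1 `CCc1ccc(C(=O)NC[C@H]2c3[nH]c4ccccc4c3C[C@H]3[C@H]4c5[nH]c6ccccc6c5C[C@@H]([C@H](C#N)N23)N4C)cc1`, gives 670 nM; the only measured step, a 2.9-fold lower number from compound 1 to compound 2 (0.46 log units; beyond the scatter), shows how far a single exchange on the carbonyl carbon moved the result. Compound 3 `COc1ccc(/C=C/C(=O)NC[C@H]2c3[nH]c4ccccc4c3C[C@H]3[C@H]4c5[nH]c6ccccc6c5C[C@@H]([C@H](C#N)N23)N4C)cc1` differs from compound 2 by 2-(4-methoxyphenyl)ethenyl in place of 1-benzofuran-2-yl on a carbonyl carbon. Going by the values given here, no measured step covers this particular exchange, so the size of that one step is the only guide. The step to compound 3 is expected to be a 2.0-fold higher number from compound 2 to compound 3 (0.29 log units; within the scatter). Compound 3 is therefore estimated at 450 nM, within a range from 150 nM to 1400 nM.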

Compound 3, half-maximal inhibitory concentration: 860 nM
Compound 3: the middle estimate sits 1.9-fold (0.28 log units) below what was measured; the measured number falls inside the stated range.
By their numbers in this assay, from the lowest: compound 2; then compounds 1 and 3 (each within the scatter of the next).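

On this carbonyl carbon, the 1-benzofuran-2-yl group of compound 2 now stands apart from two different replacements rather than one. Exchanging it for 2-(4-methoxyphenyl)ethenyl gives the larger gap so far (a 3.7-fold higher number from compound 2 to compound 3 (0.57 log units; beyond the scatter)), while 4-ethylphenyl and 2-(4-methoxyphenyl)ethenyl cannot be told apart (a 1.3-fold higher number from compound 1 to compound 3 (0.11 log units; within the scatter)). Nothing available explains why these groups compare as they do. The compounds shown leave open whether the fused ring of compound 2 matters as such, and how a simple alkyl chain or an amine on the same carbonyl carbon would compare.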